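The source may hold more compounds than are shown below. What is called first, only, known or untested is meant among the compounds shown, and "the series" means these compounds.

Compound 1 `Cc1cnc(N2CCC(c3coc4c(N5CCc6cc(S(C)(=O)=O)ccc65)ncnc34)CC2)nc1` gives 252 nM in a functional assay on cells for agonist activity at Glucose-dependent insulinotropic receptor (Homo sapiens), read by a luciferase reporter, with a stated time of 4 h; on this read-out lower numbers stand for an effect already at smaller amounts and higher numbers for an effect only at larger amounts of compound. Compound 2 `CCc1cnc(N2CCC(c3coc4c(N5CCc6cc(S(C)(=O)=O)ccc65)ncnc34)CC2)nc1` gives 41 nM. Compound 3 `CC(=O)c1cnc(N2CCC(c3coc4c(N5CCc6cc(S(C)(=O)=O)ccc65)ncnc34)CC2)nc1` gives 78 nM.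

Compound 3 stands second of the three on this read-out: it sits close to compound 2, with a 1.9-fold higher number from compound 2 to compound 3 (0.28 log units; within the scatter), and clearly apart from compound 1, with a 3.2-fold lower number from compound 1 to compound 3 (0.51 log units; beyond the scatter). Compound 4 `CC(C)(C)OC(=O)N1CCC(c2coc3c(N4CCc5cc(S(C)(=O)=O)ccc54)ncnc23)CC1` differs from compound 3 in one place: tert-butoxycarbonyl in place of 5-acetylpyrimidin-2-yl on an amine nitrogen in a ring. Among the compounds with values here, none of the measured steps bears on this change, since a 6.1-fold lower number from compound 1 to compound 2 (0.79 log units; beyond the scatter) and the others only vary a substituent on a pyrimidine that all three keep, whereas here that whole ring is removed. With no guide, compound 4 is expected to give a higher number in this assay, a 26-fold higher number from compound 3 to compound 4 (1.41 log units; beyond the scatter), and its value is estimated at 2000 nM, in a range from 300 nM to 15000 nM.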

Compound 4, half-maximal effective concentration: 53 nM
Compound 4: middle estimate off by 38-fold (1.58 log units), on the high side, outside the stated range (below it).
By their numbers in this assay, from the lowest: compounds 2, 4 and 3 (each within the scatter of the next); then compound 1.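

The pyrimidine ring on this amine nitrogen in a ring is not required for the response in this assay: tert-butoxycarbonyl, which has no ring, matches the 5-acetylpyrimidin-2-yl group (a 1.5-fold lower number from compound 3 to compound 4 (0.17 log units; within the scatter)) and the 5-ethylpyrimidin-2-yl group (a 1.3-fold higher number from compound 2 to compound 4 (0.11 log units; within the scatter)). It also gives a lower number than the 5-methylpyrimidin-2-yl group (a 4.8-fold lower number from compound 1 to compound 4 (0.68 log units; beyond the scatter)), so the pyrimidines shown do not outperform it. Nothing available explains why such different groups give matching numbers.

Going by these compounds, it remains open whether a smaller group such as methyl or acetyl, or the free amine with only hydrogen on this nitrogen, would hold this level. A benzyl group or a urea is equally untested among the compounds shown.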